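Adding a methoxy to compound 3: working notes

The source may hold more compounds than are shown below. What is called first, only, known or untested is meant among the compounds shown, and "the series" means these compounds.

- compound 1 `COc1ccc(-c2nc3sc(-c4ccccc4)cn3n2)cc1`: 38%
- compound 2 `COc1cc(-c2nc3sc(-c4ccccc4)cn3n2)cc(OC)c1OC`: 16%
- compound 3 `Clc1ccc(-c2cn3nc(-c4ccccc4)nc3s2)cc1`: 21%

All three values come from a functional assay on SF-295 cells (Homo sapiens) for inhibition, read by sulforhodamine B assay, with a stated time of 48 h, tested at 10 uM; a higher number here means more inhibition of growth at the concentration tested, a lower number less inhibition of growth. Compound 3 at 21% lies within the scatter of compound 2 and beyond the scatter under compound 1.

The next compound is compound 4 `COc1ccc(-c2nc3sc(-c4ccc(Cl)cc4)cn3n2)cc1`. It differs from compound 3 by methoxy in place of hydrogen on an aromatic carbon of a six-membered aromatic ring of carbon only, para to a large group.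

For the measured compounds named here, no measured pair differs in one place only, so this change has no direct precedent. Compound 1, which carries a methoxy, gives 38%, and this supports a small rise in this assay. Compound 2, which carries methoxy groups as well, gives 16% and goes against that reading. The rise may therefore stay within the scatter.

The expected change is a number 9 percentage points higher from compound 3 to compound 4 (within the scatter). For compound 4 the estimated value is 30%, with an expected range of 12% to 48%.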

Compound 4, percent growth inhibition at one concentration: 75.8%
Estimate against measurement, compound 4: 45.8 percentage points below, outside the stated range (above it).
By their numbers in this assay, from the lowest: compounds 2 and 3 (each within the scatter of the next); then compound 1; then compound 4.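

Notes on the result: in this assay, methoxy in place of hydrogen on an aromatic carbon, para to a large group, gives a number 54.8 percentage points higher from compound 3 to compound 4 (beyond the scatter), the first reading of this change with nothing else altered. Chloro in place of hydrogen on an aromatic carbon gives a number 37.8 percentage points higher from compound 1 to compound 4 (beyond the scatter), so removing either group from compound 4 lowers the number beyond the scatter, and the high value among these compounds goes with methoxy and chloro together. Nothing at hand explains either step.

Open: it is unclear whether the rise is particular to methoxy or would also come with an ethoxy, a hydroxyl or a dimethylamino group on the same carbon, and whether fluoro or bromo could stand in for chloro. A reading at one concentration also leaves open how compound 4 behaves across a range of concentrations.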